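This account rests on a few compounds, and the source may have more. Where it says the series, first, only, none or still open, it means among the compounds named here.

In a functional assay on PC-3 cells (Homo sapiens) for cytotoxicity, read by MTT assay, with a stated time of 72 h (a lower number here means a stronger inhibitor, a higher number a weaker inhibitor), compound 1 (`CNC(=O)c1cc(Oc2ccc(NC(=O)c3nccc(-c4ccc(OC)cc4)n3)cc2F)ccn1`) gives 24300 nM and compound 2 (`CNC(=O)c1cc(Oc2ccc(NC(=O)c3nccc(-c4ccc(C)cc4)n3)cc2)ccn1`) gives 13100 nM as its number, and the two lie within the usual scatter of each other. Going by the values given here, compound 3 (`CNC(=O)c1cc(Oc2ccc(NC(=O)c3nccc(-c4ccc(C)cc4)n3)cc2F)ccn1`) departs from compound 2 by fluoro in place of hydrogen on an aromatic carbon as its one change, fluoro in place of hydrogen on an aromatic carbon, ortho to a (2-(methylcarbamoyl)pyridin-4-yl)oxy group. Among the compounds with values here, no measured pair shows this change alone, so in this assay no shift beyond the scatter is expected, and the estimated step of a 1.1-fold higher number from compound 2 to compound 3 (0.06 log units; within the scatter) stays small. For compound 3 the expected value is 15000 nM with an estimated range from 7000 nM to 32000 nM as its likely span.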

Compound 3, half-maximal inhibitory concentration: 28400 nM
Estimate against measurement, compound 3: 1.9-fold (0.28 log units) below; the measured number falls inside the stated range.
By their numbers in this assay, from the lowest: compounds 2, 1 and 3 (each within the scatter of the next, the first and the last beyond it).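

In this assay, going by these compounds alone, fluoro in place of hydrogen on an aromatic carbon, ortho to a (2-(methylcarbamoyl)pyridin-4-yl)oxy group, gives a 2.2-fold higher number from compound 2 to compound 3 (0.34 log units; beyond the scatter), the first reading of this change alone, and a modest one. With the fluoro present, methyl in place of methoxy gives a 1.2-fold higher number from compound 1 to compound 3 (0.07 log units; within the scatter), so that swap leaves the number within the scatter. Nothing given here bears on why the fluoro shifts the number.

On these data alone, whether the fluoro step would hold with methoxy in place of the methyl stays open. So does how a chloro group at this position, or an amine in place of the methyl, would read.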